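Ethyl for methyl at the aromatic nitrogen of compound 3

A few compounds are considered here, and "the series" means these few. Any claim that something is new, unique, unknown or untested is made for them only; others in the source may bear on it.

Compound 3 `Cn1ccc(-c2ccccc2NCC2=NCCN2)n1` gives 15.9 nM in an in vitro functional assay on cells (Fibroblast) for agonist activity at Alpha-1D adrenergic receptor (Homo sapiens) (a lower number here means that less compound is needed, a higher number that more compound is needed for the effect), and stands highest of the two numbers shown; compound 1 `c1ccc(-c2nc[nH]n2)c(NCC2=NCCN2)c1` gives 3.98 nM, the step being a 4.0-fold higher number from compound 1 to compound 3 (0.60 log units; beyond the scatter). Compound 2 `Cc1n[nH]c(-c2ccccc2NCC2=NCCN2)n1` gives only a limit in this assay, < 5020 nM. The steps a step that the limit leaves unreadable from compound 1 to compound 2 and a step that the limit leaves unreadable from compound 2 to compound 3 are therefore unreadable (the limit of < 5020 nM in this assay, at which 1 of the 3 values shown sits). Compound 4 `CCn1ccc(-c2ccccc2NCC2=NCCN2)n1` differs from compound 3 by methyl in place of hydrogen on a saturated chain carbon bound to an aromatic nitrogen. Among the compounds with values here, none of the measured steps touches this chain; each exchanges the group on the aromatic carbon of the shared core, so no measured step bears on the change. A step in this assay no larger than the scatter is expected, a 1.3-fold higher number from compound 3 to compound 4 (0.10 log units; within the scatter). Compound 4 is estimated at 20 nM, range 7 nM to 60 nM.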

Compound 4, half-maximal effective concentration: < 100000 nM
Compound 4 gave a limit, no number (the forecaster's own chance of this, stated with the estimate: 3%); the middle value does not contradict the limit.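

Compound 4 gives only a limit in this assay, so the step from compound 3 to compound 4 cannot be read: the limit of < 100000 nM in this assay, at which 1 of the 4 values shown sits.

The compounds shown leave open how far the change from methyl to ethyl moves the number in this assay.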